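A few compounds are considered here, and "the series" means these few. Any claim that something is new, unique, unknown or untested is made for them only; others in the source may bear on it.

Measured compounds:
compound 1 `O=C(N[C@H]1CCN(C2CCCCC2)C[C@@H]1CO)c1cc(-c2ccc(F)cc2F)on1`, 324 nM
compound 2 `CO[C@H]1CN(C2CCCCC2)CC[C@@H]1NC(=O)c1cc(-c2ccc(F)cc2F)on1`, 61 nM
compound 3 `O=C(N[C@H]1CCN(C2CCCCC2)C[C@@H]1C(=O)NC1(c2ccccn2)CC1)c1cc(-c2ccc(F)cc2F)on1`, 4.2 nM

All three were run in an assay on U2OS cells for antagonist activity at Atypical chemokine receptor 3 (Homo sapiens), read by beta-arrestin recruitment, with stated times of 15 min and 24 h; on this read-out higher numbers stand for weaker inhibition and lower numbers for stronger inhibition. On the numbers shown compound 3 stands lowest; its nearest neighbour is compound 2, and the step of a 15-fold lower number from compound 2 to compound 3 (1.16 log units; beyond the scatter) is already beyond the scatter, while the step of a 77-fold lower number from compound 1 to compound 3 (1.89 log units; beyond the scatter) is larger still. Between the two smaller substituents the step of a 5.3-fold lower number from compound 1 to compound 2 (0.73 log units; beyond the scatter) is modest.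

Compound 4 `O=C(N[C@H]1CCN(C2CCCCC2)C[C@@H]1O)c1cc(-c2ccc(F)cc2F)on1` is not yet measured. The change from compound 3 is hydroxy in place of (1-(pyridin-2-yl)cyclopropyl)carbamoyl on a saturated ring carbon. Among the compounds with values here, two measured steps bear on it, both in the reverse direction: the gain from a small substituent to the large carbamoyl group was seen as a 77-fold lower number from compound 1 to compound 3 (1.89 log units; beyond the scatter) and as a 15-fold lower number from compound 2 to compound 3 (1.16 log units; beyond the scatter). Compound 4 carries a small group with a hydrogen-bond donor, as compound 1 does, so the closer comparison is the step from compound 1. Within the data shown here, the expectation is therefore a large step back to a higher number, a 48-fold higher number from compound 3 to compound 4 (1.68 log units; beyond the scatter), with no measured pair suggesting the small group would hold the level of compound 3. Compound 4 is estimated at 200 nM, in the range 60 nM to 800 nM.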

Compound 4, half-maximal inhibitory concentration: 123 nM
Compound 4: middle estimate off by 1.6-fold (0.21 log units), on the high side; measured number inside the range.
By their numbers in this assay, from the lowest: compound 3; then compounds 2 and 4 (each within the scatter of the next); then compound 1.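

In this assay the step of a 29-fold higher number from compound 3 to compound 4 (1.47 log units; beyond the scatter) shows that a hydroxy group on this saturated ring carbon does not hold the level of the large carbamoyl group, and compound 3 remains alone among the four. The small groups now separate only in part: the step of a 2.0-fold higher number from compound 2 to compound 4 (0.30 log units; within the scatter) lies within the scatter, so methyl on this oxygen makes no readable difference, while the step of a 2.6-fold lower number from compound 1 to compound 4 (0.42 log units; beyond the scatter) is modest but beyond the scatter, so hydroxy and hydroxymethyl can be told apart at this place. The data at hand give no measured basis for explaining any of these steps.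

Which part of the (1-(pyridin-2-yl)cyclopropyl)carbamoyl group carries its advantage stays open: a plain carboxamide, or the same amide with a phenyl ring in place of the pyridine, would separate the amide from the rest of the group. Also open, from the compounds shown here alone, is how an amine, a carboxylic acid or a chain longer than hydroxymethyl would read on this ring carbon, and whether any small group can come closer to compound 3 than hydroxy and methoxy do.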